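The compounds below may be only part of what the source reports. "The series", "measured", "known", "first", "only" and "open" are said of these compounds alone.

Measured compounds:
- compound 1 `CC(C)OC1=C(C(=O)c2ccccc2)C(c2ccc(Br)cc2)N(CCCn2ccnc2)C1=O` — 8720 nM in a functional assay on A549 cells (Homo sapiens) for antiproliferative activity, read by MTT assay, with a stated time of 72 h; on this read-out higher numbers stand for weaker inhibition and lower numbers for stronger inhibition
- compound 2 `CCCCOC1=C(C(=O)c2ccccc2)C(c2ccc(Br)cc2)N(CCCn2ccnc2)C1=O` — 18500 nM in this assay

Compound 1 stands at the lowest of the two numbers measured in this assay; its nearest neighbour is compound 2, and the step of a 2.1-fold higher number from compound 1 to compound 2 (0.33 log units; beyond the scatter) lies beyond the scatter, though it is still a modest change. That single step concerns only the size of the alkoxy group on the oxygen at the double-bonded ring carbon.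

Compound 3 `O=C(C1=C(Nc2ccc(Br)cc2)C(=O)N(CCCn2ccnc2)C1c1ccc(Br)cc1)c1ccccc1` is not yet measured. It differs from compound 1 by (4-bromophenyl)amino in place of isopropoxy on a double-bonded ring carbon. For the measured compounds named here, no measured step bears directly on this change: the only step available, from compound 1 to compound 2, exchanges one alkoxy chain for another, and tells nothing about exchanging the oxygen-linked group for a nitrogen-linked aromatic one. The expectation for this assay therefore rests on the position of compound 1 alone, with a wide range and no direction claimed beyond the scatter. Compound 3 is expected to give a step of a 1.2-fold lower number from compound 1 to compound 3 (0.10 log units; within the scatter), which is the estimate of 7000 nM with a range from 1500 nM to 30000 nM.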

Compound 3, half-maximal inhibitory concentration: 22200 nM
Beside the measured number, compound 3's estimate is 3.2-fold (0.50 log units) below it, within the range that was stated.
By their numbers in this assay, from the lowest: compound 1; then compounds 2 and 3 (each within the scatter of the next).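

Exchanging isopropoxy for (4-bromophenyl)amino on the double-bonded ring carbon gives a 2.5-fold higher number from compound 1 to compound 3 (0.41 log units; beyond the scatter) in this assay, so this position accepts a nitrogen-linked aromatic group at a modest cost relative to compound 1. Set against butoxy, the same group gives a 1.2-fold higher number from compound 2 to compound 3 (0.08 log units; within the scatter), which places a substituent carrying an aromatic ring and a hydrogen-bond donor level with butoxy and leaves compound 1 alone at the low end of the three numbers in this assay. No supporting measurement accounts for either step.

Compound 3 changes the linking atom and adds the aromatic ring in a single step, so the compounds shown cannot say which of the two sets its number; a simple isopropylamino group would address the linking atom, and an unsubstituted phenylamino group would address the bromine. It also stays open whether a smaller group such as methoxy, or a free hydroxyl, would bring this position below compound 1 in this assay, since the three substituents shown span only a narrow band of numbers.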